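The compounds below may be only part of what the source reports. "The series", "measured", "known", "first", "only" and "open" are said of these compounds alone.

Three compounds share one core and differ only in the ring at the end of the benzyloxy chain. Compound 1 `Cc1ccc(NC(=O)NC(=O)c2ccc(OCc3ccccc3)cc2)cc1-c1nc2ccccc2[nH]1` gives 35100 nM in a functional assay on MNK45 cells (Homo sapiens) for inhibition, read by MTT assay, with a stated time of 48 h; on this read-out lower numbers stand for stronger inhibition and higher numbers for weaker inhibition. Compound 2 `Cc1ccc(NC(=O)NC(=O)c2ccc(OCc3cccc(C(F)(F)F)c3)cc2)cc1-c1nc2ccccc2[nH]1`, which carries a trifluoromethyl, gives 9600 nM. Compound 3 `Cc1ccc(NC(=O)NC(=O)c2ccc(OCc3cccc(F)c3)cc2)cc1-c1nc2ccccc2[nH]1` gives 53000 nM, the highest of the three numbers, though its gap to compound 1 stays within the scatter.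

Compound 4 `Cc1ccc(NC(=O)NC(=O)c2ccc(OCc3ccc(Cl)c(Cl)c3)cc2)cc1-c1nc2ccccc2[nH]1` differs from compound 3 in one place: 3,4-dichlorophenyl in place of 3-fluorophenyl on a saturated chain carbon bound to an oxygen on an aromatic ring. Among the compounds with values here, two measured steps bear on it. The step of a 1.5-fold higher number from compound 1 to compound 3 (0.18 log units; within the scatter) shows that a single fluoro changed little, while the step of a 5.5-fold higher number from compound 2 to compound 3 (0.74 log units; beyond the scatter) shows that a bulkier trifluoromethyl on the same ring gave a clearly lower number than fluoro. Placing two chlorines on that ring is a larger change than one fluoro, so a modest drop in this assay is expected, on the order of the step of a 3.5-fold lower number from compound 3 to compound 4 (0.55 log units; beyond the scatter). Compound 4 is therefore estimated at 15000 nM, within a range of 5000 nM to 45000 nM.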

Compound 4, half-maximal inhibitory concentration: 5820 nM
For compound 4 the middle estimate is 2.6-fold (0.41 log units) above the measured one; the measured number falls inside the stated range.
By their numbers in this assay, from the lowest: compounds 4 and 2 (each within the scatter of the next); then compounds 1 and 3 (each within the scatter of the next).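

In this assay, the 3,4-dichlorophenyl group lowers the number beyond the scatter relative to the plain phenyl (a 6.0-fold lower number from compound 1 to compound 4 (0.78 log units; beyond the scatter)) and relative to 3-fluorophenyl (a 9.1-fold lower number from compound 3 to compound 4 (0.96 log units; beyond the scatter)). This gives the position a second group, besides 3-(trifluoromethyl)phenyl, that clearly beats phenyl, while the two cannot be told apart (a 1.6-fold lower number from compound 2 to compound 4 (0.22 log units; within the scatter)); compound 3 goes against any idea that every substituted ring helps. Nothing at hand explains why these rings differ.

On these data alone, whether one chlorine alone would give the same result remains open, as does the effect of a methoxy group or an amine on this ring. These results also come from a single cell line, so they leave open how the compounds behave in other cells.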